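A few compounds are considered here, and "the series" means these few. Any claim that something is new, unique, unknown or untested is made for them only; others in the source may bear on it.

Measured in a functional assay on A549 cells (Homo sapiens) for antiproliferative activity, read by MTT assay, with a stated time of 48 h; on this read-out lower numbers stand for stronger inhibition and higher numbers for weaker inhibition:
- compound 1 `O=C(/C=C/c1ccc(C(F)(F)F)cc1)Nc1nnc(-c2ccccc2)s1` gives 1.78 ug/mL
- compound 2 `COc1ccc(/C=C/C(=O)Nc2nnc(-c3ccccc3)s2)cc1` gives 0.76 ug/mL
- compound 3 `O=C(/C=C/c1ccc(F)cc1)Nc1nnc(-c2ccc(Br)cc2)s1` gives 2.83 ug/mL

In this assay, compound 3 has the highest of the three numbers. Its value lies within the scatter of compound 1, however, and only compound 2 stands clearly apart from it.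

The next compound, compound 4 `O=C(/C=C/c1ccc(F)cc1)Nc1nnc(-c2ccccc2)s1`, differs from compound 3 in one place: hydrogen in place of bromo on an aromatic carbon. This is hydrogen in place of bromo on an aromatic carbon, or 4-bromophenyl to phenyl.

Going by the values given here, no measured step covers this change. Among the compounds with values here, the one step available, a 2.3-fold lower number from compound 1 to compound 2 (0.37 log units; beyond the scatter), is modest and involves methoxy in place of trifluoromethyl elsewhere in the molecule, so it offers only a guide to size. Compound 4 does share its phenyl with compound 1 at 1.78 ug/mL and compound 2 at 0.76 ug/mL, which points weakly towards a lower number, but both also differ from compound 4 at the other end of the molecule.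

A small change is therefore expected, probably not beyond the scatter, with the direction uncertain but leaning lower. The estimate amounts to an expected 1.9-fold lower number from compound 3 to compound 4 (0.28 log units; within the scatter). Compound 4 is expected to give 1.5 ug/mL, with an estimated range from 0.6 ug/mL to 3.6 ug/mL.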

Compound 4, half-maximal inhibitory concentration: 1.82 ug/mL
Compound 4: the middle estimate sits 1.2-fold (0.08 log units) below what was measured; measured number inside the range.
By their numbers in this assay, from the lowest: compound 2; then compounds 1, 4 and 3 (each within the scatter of the next).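

In this assay, the step at this aromatic carbon, a 1.6-fold lower number from compound 3 to compound 4 (0.19 log units; within the scatter), lies within the scatter, so with the rest of the molecule unchanged, bromo and hydrogen cannot be told apart at this position. Compound 4 also links this series to the earlier phenyl compounds: fluoro and trifluoromethyl cannot be told apart at the other substituted aromatic carbon, a 1.0-fold higher number from compound 1 to compound 4 (0.01 log units; within the scatter), whereas methoxy stands apart from fluoro there, a 2.4-fold higher number from compound 2 to compound 4 (0.38 log units; beyond the scatter), a modest step beyond the scatter that matches the size of the earlier methoxy step, a 2.3-fold lower number from compound 1 to compound 2 (0.37 log units; beyond the scatter). Nothing available here bears on the reason for any of these steps.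

The compounds shown leave open whether bromo and hydrogen would remain indistinguishable if methoxy took the place of fluoro, as the bromo-for-hydrogen change has been seen only with fluoro at the other end of the molecule. They also leave open how a larger departure at the position para to a large group, such as an amine or a carboxylic acid in place of bromo, would read in this assay.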